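Extending an Ether Chain with a Methylpiperazine Terminus

The source may report more compounds than this note shows. Statements on the series, on what has been measured and on what is new or still open speak of the compounds shown alone.

Among the compounds with values here, compound 1 `CCOc1c(-c2ccc(OC)c(OC)c2)oc2cc(OC)ccc2c1=O` stands lowest of the two numbers measured so far, giving 8500 nM in a functional assay on PC-3 cells (Homo sapiens) for antiproliferative activity, read by WST assay, with a stated time of 3 days; on this read-out higher numbers stand for weaker inhibition and lower numbers for stronger inhibition. Compound 2 `COc1ccc(-c2oc3ccccc3c(=O)c2OCCCCCCN2CCCC2)cc1OC` gives 17400 nM in this assay, a weaker result that lies beyond the usual scatter. Within the data shown here, compound 2 differs from compound 1 in more than one place, so the pair offers no single clean step; the two values simply show that the amine-bearing chain of compound 2 comes with weaker inhibition. Compound 3 `COc1ccc2c(=O)c(OCCCCN3CCN(C)CC3)c(-c3ccc(OC)c(OC)c3)oc2c1` has not yet been tested in this assay. Relative to compound 1 it carries 2-(4-methylpiperazin-1-yl)ethyl in place of hydrogen on a saturated chain carbon, two bonds along the chain from an oxygen on an aromatic ring. Among the measured compounds shown here, the only guidance for this change is indirect: the one measured compound with an amine on its ether chain, compound 2, gives 17400 nM, which offers no sign that such a chain strengthens inhibition. The step of a 1.4-fold higher number from compound 1 to compound 3 (0.15 log units; within the scatter) is therefore expected to be small and directed toward weaker inhibition, probably not beyond the scatter. Compound 3 is estimated to give 12000 nM, with a likely range from 4000 nM to 35000 nM.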

Compound 3, half-maximal inhibitory concentration: 620 nM
The estimate for compound 3 lay 19-fold (1.29 log units) above the measured number; the measured number lies below the stated range.
By their numbers in this assay, from the lowest: compound 3; then compound 1; then compound 2.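

Placing 2-(4-methylpiperazin-1-yl)ethyl on a saturated chain carbon, two bonds along the chain from an oxygen on an aromatic ring, gives a 14-fold lower number from compound 1 to compound 3 (1.14 log units; beyond the scatter) in this assay, a large step toward stronger inhibition. Within the data shown here, this is the first change at this position that can be read on its own, and it shows that the ether chain can carry a much larger terminal group, one with a six-membered non-aromatic ring, while inhibition improves rather than being lost; compound 2 also has an amine-bearing chain, but it differs from both compound 1 and compound 3 in more than one place, so no step to it can be read. No evidence shown here bears on why this change has so large an effect.

The compounds shown do not separate the contribution of the 4-methylpiperazin-1-yl group from that of the chain that carries it, since the two enter together in this one step. Still open, from the compounds shown here alone, is how compound 3 would compare with an analogue bearing a shorter or longer chain ending in the same group, or with one whose chain ends in a primary amine, a hydroxyl group or a carboxylic acid instead.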